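Removal of the ring hydroxy in the oxan-4-yl series

This account rests on a few compounds, and the source may have more. Where it says the series, first, only, none or still open, it means among the compounds named here.

Compound 1 `Cc1nn2c(O)cc(C3CCOCC3)nc2c1Cc1cccc(C(F)(F)F)c1C` is the lower of the two numbers measured in an assay on isolated protein for inhibition of phosphatidylinositol 4,5-bisphosphate 3-kinase catalytic subunit beta isoform (Homo sapiens) (a higher number here means a weaker inhibitor, a lower number a stronger inhibitor), giving 3.98 nM. Among the measured compounds shown here, compound 2 `Cc1nn2c(O)cc(N3CCOCC3=O)nc2c1Cc1cccc(C(F)(F)F)c1C` gives 316 nM in this assay; the one measured step, a 79-fold higher number from compound 1 to compound 2 (1.90 log units; beyond the scatter), concerns the oxan-4-yl group and not the hydroxy. Compound 3 `Cc1nn2ccc(C3CCOCC3)nc2c1Cc1cccc(C(F)(F)F)c1C` keeps the oxan-4-yl group of compound 1 and differs only in hydrogen in place of hydroxy on an aromatic carbon. No measured step touches this position, so the size of the change is not anchored by any shown pair. With the hydroxy gone from the core of compound 1, a step in this assay toward a higher number is expected for compound 3, though its size is open. Compound 3 is therefore estimated at 30 nM in this assay, within a range of 3 nM to 300 nM. That estimate for compound 3 means a 7.5-fold higher number from compound 1 to compound 3 (0.88 log units; beyond the scatter).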

Compound 3, half-maximal inhibitory concentration: 794 nM
Estimate against measurement, compound 3: 26-fold (1.42 log units) below, outside the stated range (above it).
By their numbers in this assay, from the lowest: compound 1; then compound 2; then compound 3.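

Hydrogen in place of hydroxy on an aromatic carbon, next to the ring nitrogen, gives in this assay a 200-fold higher number from compound 1 to compound 3 (2.30 log units; beyond the scatter) and is the first reading on this position. Together with a 79-fold higher number from compound 1 to compound 2 (1.90 log units; beyond the scatter) at the oxan-4-yl group, this marks two separate places on the core of compound 1 where a single change gives a large step beyond the scatter. The data at hand offer no evidence on what lies behind the step at the hydroxy position.

On these data alone, whether a methoxy, an amine or a fluorine at this position would stay near compound 1 or near compound 3 remains open. Also open is whether removing the hydroxy gives a step of similar size alongside the 3-oxomorpholin-4-yl group of compound 2, since the shown pair covers only the oxan-4-yl series.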